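This account rests on a few compounds, and the source may have more. Where it says the series, first, only, none or still open, it means among the compounds named here.

All four compounds share one core, and each carries a different group on an amide-type nitrogen. Compound 1 `CCNC(=O)CCc1cccc2c1B(O)OC2` bears ethyl there. In a functional assay on MDA-MB-231 cells (Homo sapiens) for antiproliferative activity, read by MTT assay, with a stated time of 72 h (on this read-out higher numbers stand for weaker inhibition and lower numbers for stronger inhibition), compound 1 gives only a limit, > 100000 nM (the limit of > 100000 nM in this assay, at which 1 of the 3 values shown sits). Compound 2 `Cc1ccc(NC(=O)CCc2cccc3c2B(O)OC3)cc1` bears 4-methylphenyl, and in this assay compound 2 gives 1100 nM. Compound 3 `O=C(CCc1cccc2c1B(O)OC2)Nc1cccc(I)c1` bears 3-iodophenyl; in this assay compound 3 gives 5300 nM, the higher of the two numbers, with compound 2 as its nearest neighbour. Both steps away from compound 1 were large: an at least 90-fold lower number from compound 1 to compound 2 (1.95 log units; beyond the scatter) and an at least 18-fold lower number from compound 1 to compound 3 (1.27 log units; beyond the scatter). Between the two compounds bearing a substituted phenyl the step was modest: a 4.8-fold higher number from compound 2 to compound 3 (0.68 log units; beyond the scatter).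

Compound 4 `O=C(CCc1cccc2c1B(O)OC2)Nc1cccc(-c2cccc(C(F)(F)F)c2)c1` differs from compound 3 in a single place: 3-(trifluoromethyl)phenyl in place of iodo on an aromatic carbon. Within the data shown here, no measured step tests a second aromatic ring at this position. The step that bears most on it is a 4.8-fold higher number from compound 2 to compound 3 (0.68 log units; beyond the scatter), which shows that exchanging the substituent on the phenyl moved the number by a modest amount; the large steps from compound 1 concern the loss of the phenyl altogether and do not apply. A modest step, in either direction, is therefore expected in this assay. Compound 4 is expected to give about 4000 nM, within a range of 1000 nM to 16000 nM. That estimate corresponds to a 1.3-fold lower number from compound 3 to compound 4 (0.12 log units; within the scatter).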

Compound 4, half-maximal inhibitory concentration: 410 nM
Compound 4: middle estimate off by 9.8-fold (0.99 log units), on the high side; the whole stated range lies above it.
By their numbers in this assay, from the lowest: compound 4; then compound 2; then compound 3. At a limit, above all of these: compound 1.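

In this assay, replacing iodo with 3-(trifluoromethyl)phenyl on an aromatic carbon, a change from a single heavy atom to a group of 10 heavy atoms that includes a six-membered aromatic ring, produced a large change: a 13-fold lower number from compound 3 to compound 4 (1.11 log units; beyond the scatter). The earlier exchange of substituents on the phenyl had shown only a modest change, a 4.8-fold higher number from compound 2 to compound 3 (0.68 log units; beyond the scatter), so compound 4 adds the finding that this position accepts a much larger group and that the number in this assay can fall substantially when it does. Nothing offered here accounts for the size of this step.

The compounds shown leave open whether the lower number of compound 4 depends on the second aromatic ring itself or on the trifluoromethyl group it carries, a question that an unsubstituted phenyl at the same place would address. They also leave open whether a saturated ring such as cyclohexyl, or a second phenyl bearing an amine or a carboxylic acid instead of trifluoromethyl, would give a similar number.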